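Piperazine for piperidine on a quinazoline anilinoaryl series

The compounds below may be only part of what the source reports. "The series", "measured", "known", "first", "only" and "open" are said of these compounds alone.

Compound 1, `COc1cc2c(Nc3ccc(C#N)cc3)ncnc2cc1OCCCN1CCC(C)CC1`, in a functional assay on MCF7 cells (Homo sapiens) for antiproliferative activity, read by MTT assay, with a stated time of 72 h (on this read-out lower numbers stand for stronger inhibition and higher numbers for weaker inhibition), gives 43100 nM.
Compound 2, `COc1cc2c(Nc3ccc(C#N)cc3)ncnc2cc1OCCCN1CCN(C)CC1`, in this assay gives 71100 nM.
Compound 3, `COc1cc2c(Nc3cccc(C#N)c3)ncnc2cc1OCCCN1CCC(C)CC1`, in this assay gives 24400 nM.

The three measured compounds share one core and differ at two places. Between compound 1 and compound 2 the difference is 4-methylpiperazin-1-yl in place of 4-methylpiperidin-1-yl on a saturated chain carbon, three bonds along the chain from an oxygen on an aromatic ring, and that change made a 1.6-fold higher number from compound 1 to compound 2 (0.22 log units; within the scatter). Between compound 1 and compound 3 the cores are rearranged rather than changed in composition: 3-cyanophenyl in place of 4-cyanophenyl on a nitrogen on an aromatic ring, which made a 1.8-fold lower number from compound 1 to compound 3 (0.25 log units; within the scatter). Compound 3 carries the lowest of the three numbers; compound 1 sits nearest to it, within the scatter, while compound 2 lies further away, beyond it.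

Compound 4, `COc1cc2c(Nc3cccc(C#N)c3)ncnc2cc1OCCCN1CCN(C)CC1`, has not yet been measured. It differs from compound 3 by 4-methylpiperazin-1-yl in place of 4-methylpiperidin-1-yl on a saturated chain carbon, three bonds along the chain from an oxygen on an aromatic ring. The place of this change is described in the same words as for the change from compound 1 to compound 2, so it is the same change, seen here for the second time, now on the core of compound 3. Among the measured compounds shown here, with only one earlier example to rest on, the expectation for compound 4 in this assay is a step of about a 1.6-fold higher number from compound 3 to compound 4 (0.20 log units; within the scatter), beside the earlier step of a 1.6-fold higher number from compound 1 to compound 2 (0.22 log units; within the scatter), because that earlier step was the small rise of a 1.6-fold higher number from compound 1 to compound 2 (0.22 log units; within the scatter). Compound 4 is therefore estimated at 39000 nM, with a likely range from 18000 nM to 85000 nM.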

Compound 4, half-maximal inhibitory concentration: 23100 nM
Estimate against measurement, compound 4: 1.7-fold (0.23 log units) above; measured number inside the range.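

In this assay, putting 4-methylpiperazin-1-yl in place of 4-methylpiperidin-1-yl on the core of compound 3 gave a 1.1-fold lower number from compound 3 to compound 4 (0.02 log units; within the scatter), and this step does not differ measurably from the one seen for the same change on the core of compound 1: the same change on two cores in this assay, a 1.6-fold higher number (0.22 log units; within the scatter) from compound 1 to compound 2 and a 1.1-fold lower number (0.02 log units; within the scatter) from compound 3 to compound 4, 1.7-fold (0.24 log units) apart, within the scatter of two such steps. Among the compounds shown here, putting 3-cyanophenyl in place of 4-cyanophenyl with the 4-methylpiperazin-1-yl group present gave a 3.1-fold lower number from compound 2 to compound 4 (0.49 log units; beyond the scatter), and although only this step lies beyond the scatter, it does not differ measurably from the step for the same change with 4-methylpiperidin-1-yl present: the same change on two cores in this assay, a 1.8-fold lower number (0.25 log units; within the scatter) from compound 1 to compound 3 and a 3.1-fold lower number (0.49 log units; beyond the scatter) from compound 2 to compound 4, 1.7-fold (0.24 log units) apart, within the scatter of two such steps. The two changes therefore carried over between these cores within the limits of the data, but this rests on a single pair of steps for each change in one cell assay, and it does not show that either change would carry over to any other core in the series.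

The compounds shown leave open whether the same agreement would hold with a morpholine ring, a dimethylamino group or a longer chain in place of the 3-(4-methylpiperazin-1-yl)propyl group. They also leave open how a chlorine atom or an ethynyl group would compare with the nitrile on the phenyl ring.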